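Working notes: swapping the fused amine arm for benzothiazole

The source may hold more compounds than are shown below. What is called first, only, known or untested is meant among the compounds shown, and "the series" means these compounds.

Compound 1 `c1ccc2c(c1)CN[C@H](CN(CCCN1CCNCC1)[C@H]1CCCc3cccnc31)C2`: 1150 nM
Compound 2 `c1ccc2c(c1)CN[C@@H](CN(CCCN1CCNCC1)[C@H]1CCCc3cccnc31)C2`: 17 nM
Compound 3 `c1cnc2c(c1)CN[C@H](CN(CCCN1CCNCC1)[C@H]1CCCc3cccnc31)C2`: 2640 nM

In a functional assay on CCRF-CEM cells for antagonist activity at C-X-C chemokine receptor type 4 (Homo sapiens), read by calcium flux, with stated times of 25 min and 90 s (a lower number here means a stronger inhibitor, a higher number a weaker inhibitor), compound 3 stands highest of the three. Its nearest neighbour is compound 1, with a 2.3-fold higher number from compound 1 to compound 3 (0.36 log units; beyond the scatter); the furthest is compound 2, with a 160-fold higher number from compound 2 to compound 3 (2.19 log units; beyond the scatter). The gap between those two is a 68-fold lower number from compound 1 to compound 2 (1.83 log units; beyond the scatter), and (the fact that compounds 1 and 2 differ only in the configuration as drawn). Compound 4 `c1cnc2c(c1)CCC[C@@H]2N(CCCN1CCNCC1)Cc1nc2ccccc2s1` carries a group of 9 heavy atoms (7 carbon, 1 nitrogen, 1 sulfur; one five-membered aromatic ring with 2 hetero atoms, one six-membered aromatic ring of carbon only) in place of a group of 10 heavy atoms (8 carbon, 2 nitrogen; one six-membered non-aromatic ring with 1 hetero atom, one six-membered aromatic ring with 1 hetero atom), on a saturated chain carbon bound to an amine nitrogen. Within the data shown here, no measured step bears directly on this: the steps from compound 1 and from compound 2 to compound 3 exchange only a ring nitrogen at the same place, and the step from compound 1 to compound 2 turns only a stereocentre. The direction is therefore open; a modest step of a 4.4-fold lower number from compound 3 to compound 4 (0.64 log units; beyond the scatter) is estimated, with wide uncertainty. Compound 4 is expected to give 600 nM, between 60 nM and 6000 nM.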

Compound 4, half-maximal inhibitory concentration: 1200 nM
Estimate against measurement, compound 4: 2.0-fold (0.30 log units) below; measured number inside the range.
By their numbers in this assay, from the lowest: compound 2; then compounds 1 and 4 (each within the scatter of the next); then compound 3.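

In this assay, 1,3-benzothiazol-2-yl on a saturated chain carbon bound to an amine nitrogen gives a 2.2-fold lower number from compound 3 to compound 4 (0.34 log units; beyond the scatter) as a modest step, while a 1.0-fold higher number from compound 1 to compound 4 (0.02 log units; within the scatter) shows no separation from the arm of compound 1. The same group does not reach the arm of compound 2, with a 71-fold higher number from compound 2 to compound 4 (1.85 log units; beyond the scatter) as a large step, so a fused aromatic arm at this place has so far matched only the weaker arms. Nothing measured here explains these steps. Open, on these data alone, is whether an amine on the benzothiazole, or a longer chain to it, would narrow the gap to compound 2.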